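A methoxy on the core: solubility of compound 4

The compounds below may be only part of what the source reports. "The series", "measured", "known", "first", "only" and "open" are said of these compounds alone.

For the measured compounds named here, compound 2 `COc1cncc(-c2cccc(-c3cn4cccc(C(N)=O)c4n3)c2)c1` is one of three compounds measured in a physicochemical assay for solubility, in phosphate buffer, with a stated time of 24 h, at pH 7.4; a lower number here means a less soluble compound, a higher number a more soluble compound. In this assay compound 2 gives < 1000 nM, and that reading is a limit of the assay, not a number. Compound 1 `NC(=O)c1cccn2cc(-c3cccc(-c4cccc(F)c4)c3)nc12` gives < 1000 nM in this assay, again a limit, so the step that the two limits leave unreadable from compound 1 to compound 2 cannot be read. Compound 3 `NC(=O)c1cccn2cc(-c3cccc(-c4cncc(OC[C@H]5CCCO5)c4)c3)nc12` gives 5300 nM in this assay, and the step of an at least 5.3-fold higher number from compound 2 to compound 3 (0.72 log units; beyond the scatter) is the only readable one, with the limit of < 1000 nM in this assay, at which 2 of the 3 values shown sit, marking where the other two values sit.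

Compound 4 `COc1cncc(-c2cccc(-c3cn4ccc(OC)c(C(N)=O)c4n3)c2)c1` differs from compound 2 by methoxy in place of hydrogen on an aromatic carbon, the change sitting on an aromatic carbon of a six-membered aromatic ring with one nitrogen, part of a fused system of two rings, ortho to a carbamoyl group. Going by the values given here, none of the measured steps touches this ring or adds a methoxy, so the readable step from compound 2 to compound 3 does not bear on it and gives no direction. Compound 4 is therefore expected to stay close to compound 2, with a step that the limit leaves unreadable from compound 2 to compound 4 as the estimated step. The estimate for compound 4 in this assay is 900 nM, within a range from 200 nM to 4000 nM.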

Compound 4, solubility: 40000 nM
Estimate against measurement, compound 4: 44-fold (1.65 log units) below, and the stated range ends below it.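

Compound 4 shows that this position on the shared core, an aromatic carbon ortho to a carbamoyl group and opposite the ring nitrogen, is not silent in this assay: methoxy in place of hydrogen here gives an at least 40-fold higher number from compound 2 to compound 4 (1.60 log units; beyond the scatter). For the compounds shown here, the earlier compounds differed only in the 3-fluorophenyl or 5-methoxypyridin-3-yl part and its chain, and their one readable step, an at least 5.3-fold higher number from compound 2 to compound 3 (0.72 log units; beyond the scatter), came from oxolan-2-yl in place of hydrogen on a saturated chain carbon, so the new step is the first to show that a change on the core itself, with only 2 heavy atoms entering, can move this read-out. Going by these compounds, the full size of the step stays open because compound 2 sits at a limit of the assay and not at a number: the limit of < 1000 nM in this assay, at which 2 of the 4 values shown sit.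

On these data alone, whether the same step would appear with a hydroxy, an amine or a longer chain such as ethoxy on this carbon remains open, as does whether it would hold with the oxolan-2-yl chain of compound 3 on the same core. The step from compound 1 to compound 2 still cannot be read.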